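From Amino to Nitro: An Expectation for Compound 4

The source may hold more compounds than are shown below. What is called first, only, known or untested is meant among the compounds shown, and "the series" means these compounds.

Three compounds were measured in an assay on isolated protein for inhibition of Aromatase (Homo sapiens), read by fluorescence, using NADPH, with a stated time of 30 min, tested at 50 uM; on this read-out higher numbers stand for more inhibition at the one concentration tested (going by the name of the read-out) and lower numbers for less inhibition:
compound 1, `Cn1c(-c2ccc(Cl)c(Cl)c2)cc2cc(N)ccc21`, gives 42%;
compound 2, `O=[N+]([O-])c1ccc2[nH]c(-c3cccnc3)cc2c1`, gives 27.9%;
compound 3, `Cc1ccccc1-c1cc2cc([N+](=O)[O-])ccc2[nH]1`, gives 71.5%.

Compound 1 stands second highest of the three. Compound 2 lies below it by a margin beyond the scatter, and compound 3 lies above it, also beyond the scatter. Compound 4, `Cn1c(-c2ccc(Cl)c(Cl)c2)cc2cc([N+](=O)[O-])ccc21`, is not yet measured. It differs from compound 1 in one place: nitro in place of amino on an aromatic carbon. For the measured compounds named here, no measured pair isolates this change; compounds 2 and 3, which both carry nitro, sit on opposite sides of compound 1, so the data give no direction. The author expects a small upward step, a number 8 percentage points higher from compound 1 to compound 4 (within the scatter), within the usual scatter. Compound 4 is therefore estimated at 50%, with a range from 25% to 75%.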

Compound 4, a percentage reported as inhibition, at one concentration (the size of the read-out at that concentration, not a potency): 34%
Compound 4: middle estimate off by 16 percentage points, on the high side; the range from low to high includes it.
By their numbers in this assay, from the lowest: compounds 2, 4 and 1 (each within the scatter of the next, the first and the last beyond it); then compound 3.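

For the compounds shown here, compound 1 and compound 4 form the first pair that isolates this change: in this assay, nitro in place of amino on an aromatic carbon gives a number 8 percentage points lower from compound 1 to compound 4 (within the scatter) and so does not separate the two groups at this position on this core. Nothing shown here bears on a cause for this result.

On these data alone, whether a carboxylic acid or a nitrile at the same place would give a step beyond the scatter remains open. So does whether amino in place of nitro would give a comparable step on the cores of compound 2 and compound 3.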